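The compounds below may be only part of what the source reports. "The series", "measured", "known", "first", "only" and "open" are said of these compounds alone.

Measured so far:
- compound 1: `COc1cc(-c2cc(/C=C/C(=O)c3ccc(Cl)c(Cl)c3)[nH]n2)cc(OC)c1OC` — 8340 nM
- compound 2: `COc1ccc(C(=O)/C=C/c2cc(-c3cc(OC)c(OC)c(OC)c3)n[nH]2)cc1OC` — 1330 nM

In a functional assay on TK-10 cells (Homo sapiens) for inhibition, read by sulforhodamine B assay, with a stated time of 48 h (on this read-out higher numbers stand for weaker inhibition of growth and lower numbers for stronger inhibition of growth), compound 2 holds the lowest of the two numbers shown; its nearest neighbour is compound 1, and the single measured step, a 6.3-fold lower number from compound 1 to compound 2 (0.80 log units; beyond the scatter), separates them. Compound 3, `COc1ccc(C(=O)/C=C/c2cc(-c3cc(OC)c(OC)c(OC)c3)n[nH]2)cc1`, differs from compound 2 by one change: hydrogen in place of methoxy on an aromatic carbon, on an aromatic carbon of a six-membered aromatic ring of carbon only, ortho to a methoxy group and meta to a large group. Among the compounds with values here, the only step measured so far exchanged the whole aryl group on the carbonyl carbon, so it bears on this change only loosely; no measured pair shows the loss of a single methoxy. Compound 3 is therefore expected to move by a 1.9-fold higher number from compound 2 to compound 3 (0.27 log units; within the scatter), a step that may not exceed the scatter. The estimate for compound 3 in this assay is 2500 nM, with a range of 800 nM to 8000 nM.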

Compound 3, concentration for 50% growth inhibition: 2220 nM
Estimate against measurement, compound 3: 1.1-fold (0.05 log units) above, within the range that was stated.
By their numbers in this assay, from the lowest: compounds 2 and 3 (each within the scatter of the next); then compound 1.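

In this assay, cutting 3,4-dimethoxyphenyl back to 4-methoxyphenyl on the carbonyl carbon gives a 1.7-fold higher number from compound 2 to compound 3 (0.22 log units; within the scatter), so the loss of this one methoxy cannot be told from the scatter, and compound 2 and compound 3 cannot be ordered. The 4-methoxyphenyl group still stands apart from 3,4-dichlorophenyl, with a 3.8-fold lower number from compound 1 to compound 3 (0.57 log units; beyond the scatter), which shows that the separation from compound 1 does not depend on having both methoxy groups on this ring. No measurement is at hand that would explain either step.

What the compounds shown leave open is whether the remaining methoxy matters at all, since no compound here carries a bare phenyl on the carbonyl carbon. Going by these compounds, it also remains open whether a hydroxy group, an amine or a longer ether chain could stand in its place without moving the number beyond the scatter.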